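This account rests on a few compounds, and the source may have more. Where it says the series, first, only, none or still open, it means among the compounds named here.

Measured in a functional assay on HT-1080 cells (Homo sapiens) for cytotoxicity, read by MTT assay, with a stated time of 72 h; on this read-out higher numbers stand for weaker inhibition and lower numbers for stronger inhibition:

compound 1 `COc1cccc(/C=C2\CCC/C(=C\c3ccccc3Cl)C2=O)c1OC` gives 11700 nM
compound 2 `COc1cccc(/C=C2\CCC/C(=C\c3cccc(Cl)c3)C2=O)c1OC` gives 10300 nM
compound 3 `COc1cccc(/C=C2\CCC/C(=C\c3cccc(Br)c3)C2=O)c1OC` gives 12200 nM

Compound 3 stands level with the other two compounds, since neither gap leaves the scatter. These gaps are a 1.0-fold higher number from compound 1 to compound 3 (0.02 log units; within the scatter) and a 1.2-fold higher number from compound 2 to compound 3 (0.07 log units; within the scatter).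

The next compound is compound 4 `COc1cccc(/C=C2\CCC/C(=C\c3cccc(OC)c3OC)C2=O)c1`, which has not yet been measured. It differs from compound 3 by methoxy in place of bromo on an aromatic carbon, which in words is methoxy in place of bromo on an aromatic carbon, the 3-bromophenyl becoming 3-methoxyphenyl.

The closest evidence is the exchange of halogen at that same place, a 1.2-fold higher number from compound 2 to compound 3 (0.07 log units; within the scatter). Moving the halogen also gave little, as seen in a 1.1-fold lower number from compound 1 to compound 2 (0.06 log units; within the scatter). All three steps stay within the scatter, so these three compounds show no sensitivity to the substituent on this ring. None of them carries a methoxy at that place, however, so the evidence for this particular exchange is indirect and the range must stay wide. No step beyond the scatter is expected in this assay, and no firm direction can be given. The expected change is a 1.2-fold lower number from compound 3 to compound 4 (0.09 log units; within the scatter). Compound 4 is estimated at 10000 nM. The expected range for compound 4 runs from 4500 nM to 20000 nM.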

Compound 4, half-maximal inhibitory concentration: 9900 nM
For compound 4 the middle estimate is 1.0-fold (0.00 log units) above the measured one, and the stated range covers the measured number.
By their numbers in this assay, from the lowest: compounds 4, 2, 1 and 3 (each within the scatter of the next).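

In this assay, methoxy at this aromatic carbon now has a direct reading, and it behaves like the halogens, whether it replaces bromo (a 1.2-fold lower number from compound 3 to compound 4 (0.09 log units; within the scatter)) or chloro (a 1.0-fold lower number from compound 2 to compound 4 (0.02 log units; within the scatter)). The same holds when the 3-methoxyphenyl is set against the 2-chlorophenyl (a 1.2-fold lower number from compound 1 to compound 4 (0.07 log units; within the scatter)). The insensitivity seen among the halogen compounds therefore extends, across these four compounds, to a group with one more heavy atom and a hydrogen-bond acceptor, which bromo lacks, though no measurement is available here that would explain this tolerance.

The compounds shown leave open whether a group of another kind at this place, such as an amine or a carboxylic acid, would also leave the number where it is. They also leave open whether a longer chain in place of the methoxy, such as butoxy, or a change elsewhere on the shared core would produce a step beyond the scatter in this assay at all.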